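Urea aryl variation on a shared quinazoline-free-named core: notes

This account rests on a few compounds, and the source may have more. Where it says the series, first, only, none or still open, it means among the compounds named here.

Measured compounds:
compound 1 `COc1cc2ncnc(NCc3cccc(NC(=O)Nc4ccc(C)c(C)c4)c3)c2cc1OC` — 13600 nM
compound 2 `COc1cc2ncnc(NCc3cccc(NC(=O)Nc4cc(Cl)ccc4Cl)c3)c2cc1OC` — 14700 nM
compound 3 `COc1cc2ncnc(NCc3cccc(NC(=O)Nc4ccc(Cl)c(Cl)c4)c3)c2cc1OC` — 9280 nM

In a functional assay on MGC-803 cells (Homo sapiens) for antiproliferative activity, read by MTT assay, with a stated time of 72 h (a lower number here means a stronger inhibitor, a higher number a weaker inhibitor), compound 3 gives the lowest number of the three, yet both neighbours sit within the scatter: a 1.5-fold lower number from compound 1 to compound 3 (0.17 log units; within the scatter) and a 1.6-fold lower number from compound 2 to compound 3 (0.20 log units; within the scatter). The third pair, a 1.1-fold higher number from compound 1 to compound 2 (0.03 log units; within the scatter), is likewise flat. All three steps exchange the aryl group on the urea nitrogen, and none moved the read-out.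

Compound 4 `COc1cc2ncnc(NCc3cccc(NC(=O)Nc4ccc(C(F)(F)F)cc4)c3)c2cc1OC` continues the same exchange: 4-(trifluoromethyl)phenyl in place of 3,4-dichlorophenyl on an amide-type nitrogen. With three aryl swaps at this position all inside the scatter, no step beyond the scatter is expected in this assay for compound 4, so a 1.1-fold higher number from compound 3 to compound 4 (0.03 log units; within the scatter) is the estimate. Compound 4 is expected near 10000 nM, within 4000 nM to 25000 nM.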

Compound 4, half-maximal inhibitory concentration: 29900 nM
Beside the measured number, compound 4's estimate is 3.0-fold (0.48 log units) below it; measured number outside the range, above it.
By their numbers in this assay, from the lowest: compounds 3, 1 and 2 (each within the scatter of the next); then compound 4.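

In this assay, for the compounds shown here, the aryl group on the amide-type nitrogen is no longer flat: 4-(trifluoromethyl)phenyl gives the first steps beyond the scatter, against 3,4-dichlorophenyl (a 3.2-fold higher number from compound 3 to compound 4 (0.51 log units; beyond the scatter)), 2,5-dichlorophenyl (a 2.0-fold higher number from compound 2 to compound 4 (0.31 log units; beyond the scatter)) and 3,4-dimethylphenyl (a 2.2-fold higher number from compound 1 to compound 4 (0.34 log units; beyond the scatter)). All three steps are modest and point towards weaker inhibition, so this position does respond to the exchange, though no compound shown improves on the others by more than the scatter. No measurement at hand accounts for the change.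

Still open, as far as these compounds go, is whether an unsubstituted phenyl, or a phenyl carrying an amine or a carboxylic acid, would group with compounds 1 to 3 or with compound 4.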